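Methoxy for Methyl on the Sulfonate Aryl Ring

The compounds below may be only part of what the source reports. "The series", "measured", "known", "first", "only" and "open" are said of these compounds alone.

Measured so far:
compound 1 `Cc1ccc(OS(=O)(=O)c2ccc(N3CCN(C)C3=O)cc2)cc1` gives > 100000 nM
compound 2 `COc1ccc(OS(=O)(=O)c2ccc(N3CCN(C)C3=O)cc2)cc1` gives > 100000 nM
compound 3 `CCCN1CCN(c2ccc(S(=O)(=O)Oc3cccc(C)c3)cc2)C1=O` gives 28000 nM

In a functional assay on M21 cells (Homo sapiens) for antiproliferative activity, read by sulforhodamine B assay, with a stated time of 48 h (on this read-out higher numbers stand for weaker inhibition and lower numbers for stronger inhibition), compound 1 reaches only a limit of the assay, > 100000 nM. Compound 2 likewise reaches only a limit, > 100000 nM. For the measured compounds named here, compound 3 is the one compound with a true number, 28000 nM. The change from compound 1 to compound 2 is methoxy in place of methyl on an aromatic carbon, and the step that the two limits leave unreadable from compound 1 to compound 2 cannot be read, because of the limit of > 100000 nM in this assay, at which 2 of the 3 values shown sit. How the core of compound 3 differs from that of compound 1 is not broken down here.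

Compound 4 `CCCN1CCN(c2ccc(S(=O)(=O)Oc3cccc(OC)c3)cc2)C1=O` has not yet been measured. It differs from compound 3 by methoxy in place of methyl on an aromatic carbon. This is the same kind of change as that from compound 1 to compound 2, but the place differs: there the group sits para to a large group, here meta to a large group. The earlier step gives no readable size, so the expectation rests on compound 3 and its value 28000 nM alone. The step of a 1.3-fold higher number from compound 3 to compound 4 (0.10 log units; within the scatter) is estimated to be small, and compound 4 is expected to give about 35000 nM, with a range from 10000 nM to 120000 nM.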

Compound 4, half-maximal inhibitory concentration: 10000 nM
Beside the measured number, compound 4's estimate is 3.5-fold (0.54 log units) above it, and the stated range covers the measured number.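

In this assay, methoxy in place of methyl on the core of compound 3 gives a 2.8-fold lower number from compound 3 to compound 4 (0.45 log units; beyond the scatter), so on this core the change brings stronger inhibition. This is one measured pair on one core, and it shows nothing about whether the same gain appears on the core of compound 1, where the group also sits in a different place from the meta to a large group of compound 4. The same change from compound 1 to compound 2 cannot be read, because both compounds give only a limit, not a number: the limit of > 100000 nM in this assay, at which 2 of the 4 values shown sit.

As far as these compounds go, it remains open whether methoxy in the place it holds in compound 4 would give a readable number on the core of compound 1. From the compounds shown here alone, it is also open how an ethoxy group, a hydroxyl group or an amine in that same place would compare with methoxy on the core of compound 3.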